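Swapping an Amide for a Nitro Group on Vero Cells

The source may hold more compounds than are shown below. What is called first, only, known or untested is meant among the compounds shown, and "the series" means these compounds.

Three compounds share one core. Compound 1 `O=C(CN1CCCC1)Nc1ccc(-c2nc3cc(C(F)(F)F)ccc3[nH]2)cc1` carries a pyrrolidin-1-yl group on its side chain. In an ADME assay on Vero cells (Chlorocebus sabaeus) for cytotoxicity (a higher number here means that more compound is tolerated, a lower number that less compound is tolerated), compound 1 gives > 100000 nM, which is a limit of the assay, not a number. Compound 2 `Cn1c(-c2ccc([N+](=O)[O-])cc2)nc2cc(C(F)(F)F)ccc21` gives > 100000 nM in this assay, also a limit. Compound 3 `CCC(=O)Nc1ccc(-c2nc3cc(C(F)(F)F)ccc3[nH]2)cc1` gives > 100000 nM in this assay, again a limit. So compound 3 stands at the same limit as both others (the limit of > 100000 nM in this assay, at which 3 of the 3 values shown sit), and the step that the two limits leave unreadable from compound 1 to compound 3 has no readable size. Compound 4 `O=[N+]([O-])c1ccc(-c2nc3cc(C(F)(F)F)ccc3[nH]2)cc1` differs from compound 3 by nitro in place of propanoylamino on an aromatic carbon. Compound 2 also carries a nitro group and sits at the limit. Among the measured compounds shown here, no measured step shows any movement, so no change beyond the scatter is expected in this assay. Compound 4 is therefore expected to give 100000 nM, within a range from 50000 nM to 300000 nM. The step of a number no higher from compound 3 to compound 4 (the limit leaves the size open) implied by this estimate is expected to be flat.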

Compound 4, half-maximal cytotoxic concentration: 45000 nM
Compound 4: middle estimate off by 2.2-fold (0.35 log units), on the high side, and the stated range ends above it.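

In this assay, among the compounds shown here, nitro in place of propanoylamino on an aromatic carbon brings an at least 2.2-fold lower number from compound 3 to compound 4 (0.34 log units; beyond the scatter) and is the first movement here that can be read. Nitro in place of the longer side chain of compound 1 brings an at least 2.2-fold lower number from compound 1 to compound 4 (0.34 log units; beyond the scatter) at the same aromatic carbon. Nitro alone is not the whole story: hydrogen in place of methyl on an aromatic nitrogen brings an at least 2.2-fold lower number from compound 2 to compound 4 (0.34 log units; beyond the scatter) with the nitro group kept.

Each step starts from a limit of the assay, which leaves its full size open. On these data alone, whether an amine or a nitrile on this aromatic carbon also lowers the number stays open too.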